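Expected Acid Dissociation of a Fourth Aryl Variant

A few compounds are considered here, and "the series" means these few. Any claim that something is new, unique, unknown or untested is made for them only; others in the source may bear on it.

Measured so far in a physicochemical assay for acid dissociation:
Compound 1, `COc1cccc(CNCCCNc2ccnc3cc(Oc4cccc(N(C)C)c4)ccc23)c1O`, 9.28
Compound 2, `COc1cccc(CNCCCNc2ccnc3cc(Oc4ccc(C(C)(C)C)cc4)ccc23)c1O`, 9.28
Compound 3, `COc1cccc(CNCCCNc2ccnc3cc(Cc4cccc(C(F)(F)F)c4)ccc23)c1O`, 9.47

Compound 3 carries a 3-(trifluoromethyl)benzyl group where compounds 1 and 2 carry an aryl ether, yet its number sits apart from theirs only within the scatter: a number 0.19 log units higher from compound 1 to compound 3 (within the scatter) and a number 0.19 log units higher from compound 2 to compound 3 (within the scatter). Compound 4, `COc1ccc(-c2ccc3c(NCCCNCc4cccc(OC)c4O)ccnc3c2)cc1`, is not yet measured. It differs from compound 3 as follows: 4-methoxyphenyl in place of 3-(trifluoromethyl)benzyl on an aromatic carbon. Within the data shown here, three measured steps bear on this change, all at the same place: no change at the digits printed from compound 1 to compound 2 (within the scatter), a number 0.19 log units higher from compound 1 to compound 3 (within the scatter) and a number 0.19 log units higher from compound 2 to compound 3 (within the scatter); none of them moved this assay beyond the scatter. Because a number 0.19 log units higher from compound 2 to compound 3 (within the scatter) stayed within the scatter, as did the other two steps at this place, compound 4 is expected to show a number 0.12 log units lower from compound 3 to compound 4 (within the scatter), that is, no step beyond the scatter. Compound 4 is therefore estimated at 9.35, with a range from 9 to 9.7.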

Compound 4, acid dissociation constant: 9.47
The estimate for compound 4 lay 0.12 log units below the measured number; measured number inside the range.
By their numbers in this assay, from the lowest: compounds 1, 2, 3 and 4 (each within the scatter of the next).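

In this assay, the 4-methoxyphenyl group, with one hydrogen-bond acceptor where 3-(trifluoromethyl)benzyl has none, gives no change at the digits printed from compound 3 to compound 4 (within the scatter). Set against the two aryl ethers, it gives a number 0.19 log units higher from compound 2 to compound 4 (within the scatter) and a number 0.19 log units higher from compound 1 to compound 4 (within the scatter), so a fourth group at this aromatic carbon also stays within the scatter. Nothing measured here accounts for this flat result. As far as these compounds go, all four groups carry a six-membered aromatic ring of carbon only, so it remains open whether a carboxylic acid at this place would shift the number beyond the scatter.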